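Cyclopentane amide series: heteroaryl swap and cytotoxicity limit

This account rests on a few compounds, and the source may have more. Where it says the series, first, only, none or still open, it means among the compounds named here.

Compound 3 `O=C(O)/C=C/c1ccc(NC(=O)C2(NC(=O)c3ccc4c(c3)nc(-c3ccsc3)n4C3CCCCC3)CCC2)cc1` carries thiophen-3-yl on the shared core. In an ADME assay on Huh-7 cells (Homo sapiens) for cytotoxicity (a lower number here means that less compound is tolerated, a higher number that more compound is tolerated), compound 3 gives > 10 uM, which is a limit of the assay rather than a number. Compound 2 `O=C(O)/C=C/c1ccc(NC(=O)C2(NC(=O)c3ccc4c(c3)nc(-c3ccccc3)n4C3CCCCC3)CCC2)cc1` gives > 10 uM in this assay, also a limit. Compound 1 `O=C(O)/C=C/c1ccc(NC(=O)C2(NC(=O)c3ccc4c(c3)nc(-c3ccccn3)n4C3CCCCC3)CCCC2)cc1`, with pyridin-2-yl on the larger saturated ring, gives > 10 uM in this assay, again a limit. Among the compounds with values here, the only step between neighbours, a step that the two limits leave unreadable from compound 2 to compound 3, cannot be sized because of the limit of > 10 uM in this assay, at which 3 of the 3 values shown sit.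

Within the data shown here, compound 4 `O=C(O)/C=C/c1ccc(NC(=O)C2(NC(=O)c3ccc4c(c3)nc(-c3ccccn3)n4C3CCCCC3)CCC2)cc1` is the next member. pyridin-2-yl in place of thiophen-3-yl on an aromatic carbon Compound 1 and compound 4 share the pyridin-2-yl group; no step between them is measured, and compound 1 sits at the limit. With every value shown at the limit, no step beyond the scatter is expected in this assay for compound 4. The step that the limit leaves unreadable from compound 3 to compound 4 is therefore expected to remain unreadable against the limit. Compound 4 is expected to give 30 uM, within 10 uM to 100 uM, most likely reported again as a limit.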

Compound 4, half-maximal toxic concentration: > 10 uM
Compound 4 ended at the assay's limit (the forecaster's own chance of this, stated with the estimate: 85%); the middle value is on the limit's open side.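

The steps from compound 2 and from compound 3 to compound 4 cannot be read in this assay because every value is a limit: the limit of > 10 uM in this assay, at which 4 of the 4 values shown sit.

The compounds shown leave open where the true values lie beyond that limit, and so whether phenyl, thiophen-3-yl and pyridin-2-yl differ at all.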